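Trading Pent-1-en-1-yl for 2-Methylprop-1-en-1-yl Once More

This account rests on a few compounds, and the source may have more. Where it says the series, first, only, none or still open, it means among the compounds named here.

Compound 1, `CCC/C=C/C(=O)Nc1cccc(Oc2nc(Nc3ccn(C)n3)nc3c2CSCC3)c1`, was tested in a functional assay on MCF7 cells (Homo sapiens) for antiproliferative activity, read by MTT assay, with a stated time of 72 h (a higher number here means a weaker inhibitor, a lower number a stronger inhibitor), where compound 1 gives 22600 nM. Compound 2, `CC(C)=CC(=O)Nc1cccc(Oc2nc(Nc3ccn(C)n3)nc3c2CSCC3)c1`, carries 2-methylprop-1-en-1-yl in place of pent-1-en-1-yl on a carbonyl carbon. In this assay compound 2 reaches only a limit of the measurement, reported as > 50000 nM. The change therefore produced an at least 2.2-fold higher number from compound 1 to compound 2 (0.34 log units; beyond the scatter), a step whose true size is open because of the limit of > 50000 nM in this assay, at which 1 of the 3 values shown sits.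

Compound 3, `CCC/C=C/C(=O)Nc1cccc(Oc2nc(Nc3cccc(OC)c3)nc3c2CSCC3)c1`, keeps the pent-1-en-1-yl group of compound 1 but differs in the core, with 3-methoxyphenyl in place of 1-methyl-1H-pyrazol-3-yl on a nitrogen on an aromatic ring. In this assay compound 3 gives 32000 nM, so the two cores sit close together, with a 1.4-fold higher number from compound 1 to compound 3 (0.15 log units; within the scatter).

Compound 4, `COc1cccc(Nc2nc3c(c(Oc4cccc(NC(=O)C=C(C)C)c4)n2)CSCC3)c1`, is not yet measured. It stands to compound 3 as compound 2 stands to compound 1, with 2-methylprop-1-en-1-yl in place of pent-1-en-1-yl on a carbonyl carbon, at a place described in the same words for both pairs, so the change is the same one. For compound 4 the expectation is a step of a 2.2-fold higher number from compound 3 to compound 4 (0.34 log units; beyond the scatter) in this assay, resting on compound 1 and compound 2 having shown an at least 2.2-fold higher number from compound 1 to compound 2 (0.34 log units; beyond the scatter) with the identical change. Starting from the number of compound 3, that size of step would carry compound 4 close to, or past, the limit that compound 2 met. The estimate for compound 4 in this assay is 70000 nM, within a range from 30000 nM to 200000 nM.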

Compound 4, half-maximal inhibitory concentration: > 50000 nM
Compound 4: only a limit was reported; the forecaster's own chance of this, stated with the estimate: 65%; the middle value lies beyond the limit too.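

Set on the second core, the swap of pent-1-en-1-yl for 2-methylprop-1-en-1-yl on the carbonyl carbon gives an at least 1.5-fold higher number from compound 3 to compound 4 (0.19 log units; that floor lies within the scatter) in this assay, and this is only a floor, as compound 4, like compound 2, ended at a limit rather than a number. The two pairs fit a loss of activity that carries from one core to the other, and neither shows a gain, but the floor on the second core does not by itself establish a real step, and the sizes cannot be compared: the same change on two cores in this assay, an at least 2.2-fold higher number (0.34 log units; beyond the scatter) from compound 1 to compound 2 and an at least 1.5-fold higher number (0.19 log units; that floor lies within the scatter) from compound 3 to compound 4; the limit leaves it open whether they differ. The step from compound 2 to compound 4 cannot be read, so nothing can be said about how the 3-methoxyphenyl and 1-methyl-1H-pyrazol-3-yl groups compare when the 2-methylprop-1-en-1-yl group is present: the limit of > 50000 nM in this assay, at which 2 of the 4 values shown sit.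

From the compounds shown here alone, how far compound 2 and compound 4 really lie past their limits remains open, and so does whether the two cores respond to this change by the same amount. Also open, going by these compounds, is what other groups on the carbonyl carbon would do on either core, such as a longer chain like hept-1-en-1-yl or a chain ending in a dimethylamino group.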